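Methyl in Place of Methoxy on a Shared Core

The source may hold more compounds than are shown below. What is called first, only, known or untested is meant among the compounds shown, and "the series" means these compounds.

Compound 1 `FC(F)(F)c1ccc(CSc2nc(N3CCCCC3)c3ccccc3n2)cc1` in a functional assay on MCF7 cells (Homo sapiens) for cytotoxicity, read by MTT assay, with a stated time of 72 h (a higher number here means a weaker inhibitor, a lower number a stronger inhibitor), gives > 50000 nM, a limit of the assay rather than a number.
Compound 2 `COc1ccccc1Nc1nc(SCc2ccc(C(F)(F)F)cc2)nc2ccccc12` in this assay gives > 50000 nM, again a limit rather than a number.

For the measured compounds named here, compound 2 therefore stands at a limit only, as does the one compound it can be compared with. Going by the values given here, the single step between them, a step that the two limits leave unreadable from compound 1 to compound 2, cannot be read in size or direction, since both ends sit at the limit of > 50000 nM in this assay, at which 2 of the 2 values shown sit. Among the compounds with values here, nothing among the measured values shows whether compound 2 is a weak inhibitor just beyond the limit or has no measurable effect at all.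

Compound 3 `Cc1ccccc1Nc1nc(SCc2ccc(C(F)(F)F)cc2)nc2ccccc12` differs from compound 2 by methyl in place of methoxy on an aromatic carbon. Within the data shown here, no measured step bears on this change: the only step available is unreadable, and both compounds that have been tested sit at the same limit. What the data allow is the plain expectation that so small a change is unlikely to bring a compound from beyond the limit into the measurable range. Compound 3 is therefore estimated at 60000 nM, with a range from 15000 nM to 250000 nM, and most likely only another limit will be reported. The estimated step is a step that the limit leaves unreadable from compound 2 to compound 3, an expectation of no change beyond the scatter.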

Compound 3, half-maximal inhibitory concentration: 37500 nM
For compound 3 the middle estimate is 1.6-fold (0.20 log units) above the measured one; low and high end bracket the measured number.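

In this assay, compound 3 is the first of the three compounds to give a number instead of a limit, so this position on the aromatic ring can carry a change that brings the series into the measurable range: the limit of > 50000 nM in this assay, at which 2 of the 3 values shown sit.

Methyl in place of methoxy on this aromatic carbon gives an at least 1.3-fold lower number from compound 2 to compound 3 (0.12 log units; that floor lies within the scatter), and compound 2 has only a limit, so the true gap could be barely there or much larger. The (2-methylphenyl)amino group in place of piperidin-1-yl gives an at least 1.3-fold lower number from compound 1 to compound 3 (0.12 log units; that floor lies within the scatter), which likewise shows a floor within the scatter, so neither step alone proves that the change matters, and all that is firmly new is a measured number on the shared core.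

On these data alone, the step between compound 1 and compound 2 still cannot be read, and it remains open how far beyond the limit either compound lies. Also open, as far as these compounds go, is what a chlorine atom, a hydroxyl or an ethyl group on the same aromatic carbon would do, and whether any of them would move the number clearly beyond the scatter.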